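This account rests on a few compounds, and the source may have more. Where it says the series, first, only, none or still open, it means among the compounds named here.

Measured so far:
compound 1, `COc1ccc(NC(=O)c2nnc(COc3ccc(CCC(=O)O)cc3)s2)cc1`, with > 10000 nM in a functional assay on CHO cells for agonist activity at Free fatty acid receptor 1 (Homo sapiens), read by calcium flux; on this read-out lower numbers stand for an effect already at smaller amounts and higher numbers for an effect only at larger amounts of compound (a limit, not a number)
compound 2, `O=C(O)CCc1ccc(OCc2nnc(C(=O)Nc3ccc(Cl)cc3)s2)cc1`, with 3690 nM
compound 3, `COc1cccc(NC(=O)c2nnc(COc3ccc(CCC(=O)O)cc3)s2)c1`, with 4680 nM

Three compounds share one core and differ only in the aromatic ring carried on the amide-type nitrogen. Compound 1 reached only the limit of this assay, so its value is a limit and not a number. Compound 3 stands highest of the two real numbers, with compound 2 nearest, and the gap a 1.3-fold higher number from compound 2 to compound 3 (0.10 log units; within the scatter) lies within the scatter of repeated measurements. Both steps from compound 1 were at least modest: an at least 2.7-fold lower number from compound 1 to compound 2 (0.43 log units; beyond the scatter) and an at least 2.1-fold lower number from compound 1 to compound 3 (0.32 log units; beyond the scatter).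

Compound 4, `Cc1ccc(NC(=O)c2nnc(COc3ccc(CCC(=O)O)cc3)s2)cc1`, is not yet measured. It differs from compound 3 by 4-methylphenyl in place of 3-methoxyphenyl on an amide-type nitrogen. For the measured compounds named here, no measured step swaps a methoxy for a methyl, so the closest guidance is indirect: the one measured ring bearing a substituent at the 4-position, compound 1, gave only a limit (the limit of > 10000 nM in this assay, at which 1 of the 3 values shown sits), while the other two rings gave numbers near each other. A step of roughly a 1.2-fold higher number from compound 3 to compound 4 (0.07 log units; within the scatter) is therefore expected, with wide uncertainty. Compound 4 is estimated at 5500 nM, between 2000 nM and 15000 nM, and a limit rather than a number remains possible.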

Compound 4, half-maximal effective concentration: 4300 nM
Beside the measured number, compound 4's estimate is 1.3-fold (0.11 log units) above it, and the stated range covers the measured number.
By their numbers in this assay, from the lowest: compounds 2, 4 and 3 (each within the scatter of the next). At a limit, above all of these: compound 1.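

In this assay, putting a methyl group where the methoxy group stood gives an at least 2.3-fold lower number from compound 1 to compound 4 (0.36 log units; beyond the scatter), so this single swap on the 4-substituted ring is enough to move the result from a limit to a real number. The other two changes give a 1.2-fold higher number from compound 2 to compound 4 (0.07 log units; within the scatter) and a 1.1-fold lower number from compound 3 to compound 4 (0.04 log units; within the scatter), so neither methyl for chloro nor the swap of 3-methoxyphenyl for 4-methylphenyl separates these compounds, and compound 2, compound 3 and compound 4 cannot be told apart here. Compound 1 alone remains at a limit, which is not a number: the limit of > 10000 nM in this assay, at which 1 of the 4 values shown sits.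

From the compounds shown here alone, it remains open whether any ring on the amide-type nitrogen can bring the number far lower, for instance one carrying a trifluoromethyl group or two chloro groups rather than one small group. Going by these compounds, the chain ending in the carboxylic acid is also the same in all four compounds, so the effect of a longer chain, or of an amide in place of that acid, remains unknown.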